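Swapping fluoro for chloro on compound 3

The compounds below may be only part of what the source reports. "The series", "measured", "known", "first", "only" and "open" are said of these compounds alone.

Compound 3 `O=C(c1ccccc1F)N1CCN(c2nc(=O)c3cc(C(F)(F)F)cc([N+](=O)[O-])c3s2)CC1` stands second highest of the three numbers in a physicochemical assay for solubility, read by HPLC (on this read-out lower numbers stand for lower solubility and higher numbers for higher solubility), where compound 3 gives 3.1 ug/mL. Compound 1 `CCC(=O)N1CCN(c2nc(=O)c3cc(C(F)(F)F)cc([N+](=O)[O-])c3s2)CC1` gives 3.29 ug/mL, and the step of a 1.1-fold lower number from compound 1 to compound 3 (0.03 log units; within the scatter) is within the scatter. Compound 2 `O=C(c1cccc(F)c1)N1CCN(c2nc(=O)c3cc(C(F)(F)F)cc([N+](=O)[O-])c3s2)CC1` gives 0.2 ug/mL, and the step of a 16-fold higher number from compound 2 to compound 3 (1.19 log units; beyond the scatter) is large. Compound 4 `O=C(c1ccccc1Cl)N1CCN(c2nc(=O)c3cc(C(F)(F)F)cc([N+](=O)[O-])c3s2)CC1` differs from compound 3 in one place: chloro in place of fluoro on an aromatic carbon. Within the data shown here, no measured step contains a chloro-for-fluoro swap, so nothing here speaks directly to it, and the only step within the scatter, a 1.1-fold lower number from compound 1 to compound 3 (0.03 log units; within the scatter), concerns a different change. In this assay the step of a 1.6-fold lower number from compound 3 to compound 4 (0.19 log units; within the scatter) is therefore expected to stay modest, and compound 4 is estimated at 2 ug/mL, within a range from 0.5 ug/mL to 8 ug/mL.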

Compound 4, solubility: 8.18 ug/mL
Estimate against measurement, compound 4: 4.1-fold (0.61 log units) below; measured number outside the range, above it.
By their numbers in this assay, from the lowest: compound 2; then compounds 3 and 1 (each within the scatter of the next); then compound 4.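

In this assay the 2-fluorophenyl group could not be told apart from ethyl, but this position does respond to the atom it carries: chloro in place of fluoro gives a step beyond the scatter (a 2.6-fold higher number from compound 3 to compound 4 (0.42 log units; beyond the scatter)). The 2-chlorophenyl group also clearly separates from ethyl (a 2.5-fold higher number from compound 1 to compound 4 (0.40 log units; beyond the scatter)) and lies much further from 3-fluorophenyl (a 41-fold higher number from compound 2 to compound 4 (1.61 log units; beyond the scatter)). Nothing available explains this rise. On these data alone, whether bromo or methoxy at this position would raise the number further remains open. So does how 3-chlorophenyl would compare with 3-fluorophenyl.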